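Swapping pyridin-2-yl for pyridin-4-yl: a cytotoxicity estimate

The compounds below may be only part of what the source reports. "The series", "measured", "known", "first", "only" and "open" are said of these compounds alone.

- compound 1 `CC1=CC(C)(C)N(Cc2ccc(Cl)cc2)c2ccc(O)cc21` gives 7900 nM
- compound 2 `CC1=CC(C)(C)N(Cc2ccccn2)c2ccc(O)cc21` gives 18000 nM

In an ADME assay on L6 cells (Rattus norvegicus) for cytotoxicity, read by resazurin assay, with a stated time of 70 h (on this read-out higher numbers stand for weaker inhibition and lower numbers for stronger inhibition), compound 2 gives the higher of the two numbers, 18000 nM. For the measured compounds named here, the one measured step, which put pyridin-2-yl in place of 4-chlorophenyl, is a 2.3-fold higher number from compound 1 to compound 2 (0.36 log units; beyond the scatter). Compound 3 `CC1=CC(C)(C)N(Cc2ccncc2)c2ccc(O)cc21` keeps the shared core but carries pyridin-4-yl in place of pyridin-2-yl on the same saturated chain carbon: pyridin-4-yl in place of pyridin-2-yl on a saturated chain carbon bound to a nitrogen on an aromatic ring in a ring. Going by the values given here, the measured step involved a different exchange and was modest, and no measurement yet compares these two groups directly. No step beyond the scatter is therefore expected, and neither direction is favoured. The expected step is no change at the digits printed from compound 2 to compound 3 (within the scatter). For compound 3 the estimated value is 18000 nM, with an expected range of 8000 nM to 40000 nM.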

Compound 3, half-maximal inhibitory concentration: 13000 nM
Beside the measured number, compound 3's estimate is 1.4-fold (0.14 log units) above it, within the range that was stated.
By their numbers in this assay, from the lowest: compounds 1, 3 and 2 (each within the scatter of the next, the first and the last beyond it).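

In this assay, for the compounds shown here, exchanging pyridin-2-yl for pyridin-4-yl on the saturated chain carbon gives a 1.4-fold lower number from compound 2 to compound 3 (0.14 log units; within the scatter), the first direct comparison of these two groups. Putting pyridin-4-yl in place of 4-chlorophenyl gives a 1.6-fold higher number from compound 1 to compound 3 (0.22 log units; within the scatter), so this exchange stays within the scatter, whereas the one to pyridin-2-yl did not. No evidence is available to explain these numbers. On these data alone, whether pyridin-3-yl on the same carbon would also stay within the scatter remains open. So does the effect of an amine or a carboxylic acid there.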